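Isopropyl for Methyl on the Aryl Ring of Compound 1

The source may hold more compounds than are shown below. What is called first, only, known or untested is meant among the compounds shown, and "the series" means these compounds.

Measured in an assay on HepG2 cells for agonist activity at nuclear receptor subfamily 1 group I member 3 (Homo sapiens), read by a luciferase reporter, with a stated time of 23 h; a higher number here means that more compound is needed for the effect, a lower number that less compound is needed:
compound 1 `Cc1ccc(-c2nc3sccn3c2/C=N/OCc2ccc(Cl)c(Cl)c2)cc1` gives 490 nM
compound 2 `Clc1ccccc1CO/N=C/c1c(-c2ccc3ccccc3c2)nc2occn12` gives 1100 nM
compound 3 `FC(F)(F)c1ccc(CO/N=C/c2c(-c3ccc4ccccc4c3)nc3occn23)cc1` gives 470 nM

Compound 1 stands second highest of the three numbers in this assay. Its nearest neighbour is compound 3, whose value lies within the scatter of that of compound 1; compound 2 lies furthest away, its value beyond the scatter of compound 1. Compound 4 `CC(C)c1ccc(-c2nc3sccn3c2/C=N/OCc2ccc(Cl)c(Cl)c2)cc1` shares the core of compound 1 and differs from it in one place: isopropyl in place of methyl on an aromatic carbon.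

Going by the values given here, the only measured step, a 2.3-fold lower number from compound 2 to compound 3 (0.37 log units; beyond the scatter), concerns the aryl group on a saturated chain carbon bound to an oxygen on an unsaturated carbon, in compounds with a different core, so it does not bear on the exchange of methyl for isopropyl. Among the compounds with values here, no measured pair shows the effect of a change at this aromatic carbon. With nothing to build on, the expectation for compound 4 is a number close to that of compound 1, with no step beyond the scatter expected in either direction. The estimate for compound 4 in this assay is therefore 450 nM, with a range from 180 nM to 1100 nM. That estimate amounts to an expected step of a 1.1-fold lower number from compound 1 to compound 4 (0.04 log units; within the scatter).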

Compound 4, half-maximal effective concentration: 590 nM
Compound 4: middle estimate off by 1.3-fold (0.12 log units), on the low side; measured number inside the range.
By their numbers in this assay, from the lowest: compounds 3, 1, 4 and 2 (each within the scatter of the next, the first and the last beyond it).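

The exchange on an aromatic carbon para to a large group, 4-methylphenyl to 4-isopropylphenyl, gives a 1.2-fold higher number from compound 1 to compound 4 (0.08 log units; within the scatter) in this assay. Going by these compounds alone, this is the first pair to speak to this position, and it places compound 1 and compound 4 within the scatter of each other, so on this core the position accepts isopropyl, with its 3 heavy atoms, in place of methyl, with its 1, without a change that can be told from repeated measurement. The reading rests on this single pair, and nothing measured alongside it offers an account of why the two values stand so close.

As far as these compounds go, whether a tert-butyl group, a methoxy group, an amine or a carboxylic acid on this aromatic carbon would also stay within the scatter of compound 1 remains open. From the compounds shown here alone, how the exchange of methyl for isopropyl would read on the different core of compound 2 and compound 3 remains open as well.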